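Swapping an Amine Substituent for a Hydroxyacetyl Amide

A few compounds are considered here, and "the series" means these few. Any claim that something is new, unique, unknown or untested is made for them only; others in the source may bear on it.

Measured compounds:
- compound 1, `NC[C@@H]1CCCc2cc(S(=O)(=O)c3cn[nH]c3)ccc21`: 2 nM in an assay on isolated protein for displacement of a labelled ligand from 5-hydroxytryptamine receptor 6 (Homo sapiens); on this read-out higher numbers stand for weaker inhibition and lower numbers for stronger inhibition
- compound 2, `CN(CC(N)=O)C[C@@H]1CCCc2cc(S(=O)(=O)c3cccc(F)c3)ccc21`: 1.26 nM in this assay
- compound 3, `COCCNC[C@@H]1CCCc2cc(S(=O)(=O)c3cccc(F)c3)ccc21`: 0.251 nM in this assay

Compound 3 gives the lowest number of the three, and its gap to each of the others lies beyond the scatter, so on these values it is the strongest inhibitor. Compound 4, `O=C(CO)NC[C@@H]1CCCc2cc(S(=O)(=O)c3cccc(F)c3)ccc21`, is not yet measured. Relative to compound 3 it carries (hydroxymethyl)carbonyl in place of 2-methoxyethyl on an amine nitrogen. The nitrogen thus stops being a basic amine and becomes part of an amide.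

Going by the values given here, only one measured step touches this nitrogen: a 5.0-fold lower number from compound 2 to compound 3 (0.70 log units; beyond the scatter). That step shows the group on the nitrogen matters, but neither it nor any other measured pair shows what an amide at this position does. The change in compound 4 is therefore a step into unmapped territory. A return toward the numbers of compound 1 and compound 2 seems the more likely outcome, with wide uncertainty. Compound 4 is expected to give about 2 nM in this assay, within 0.5 nM to 8 nM, which is an estimated 8.0-fold higher number from compound 3 to compound 4 (0.90 log units; beyond the scatter).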

Compound 4, inhibition constant: 0.1 nM
The estimate for compound 4 lay 20-fold (1.30 log units) above the measured number; the measured number lies below the stated range.
By their numbers in this assay, from the lowest: compound 4; then compound 3; then compounds 2 and 1 (each within the scatter of the next).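

At this amine nitrogen, a (hydroxymethyl)carbonyl group does better than 2-methoxyethyl, with a 2.5-fold lower number from compound 3 to compound 4 (0.40 log units; beyond the scatter) in this assay, so turning the nitrogen into an amide does not cost inhibition here. The wider comparison, a 13-fold lower number from compound 2 to compound 4 (1.10 log units; beyond the scatter), shows that the choice of group at this point can shift the number by much more than the earlier step did, although this pair also differs in whether the nitrogen carries a methyl group. Nothing available explains why the amide gives the stronger inhibition.

On these data alone, it remains open whether the hydroxyl group of the new substituent matters, which a plain acetyl group on the same nitrogen would test. A longer chain bearing the hydroxyl, or a carboxylic acid in its place, would show how much room for change this position allows.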